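Neopentyl for phenyl on the hydroxyacyl side chain

This account rests on a few compounds, and the source may have more. Where it says the series, first, only, none or still open, it means among the compounds named here.

Compound 1 `O=C(NCc1cc(Cl)ccc1-n1cnnn1)[C@@H]1[C@H]2C[C@H]2CN1C(=O)[C@H](O)c1ccccc1` and compound 2 `O=C(NCc1cc(Cl)ccc1-n1cnnn1)[C@@H]1C[C@H]2C[C@H]2N1C(=O)[C@H](O)c1ccccc1` are built from the same atoms joined differently; the difference between the two cores is not broken down here. In a functional assay on a cell-free system (plasma, Homo sapiens), with a stated time of 3 min (on this read-out lower numbers stand for stronger inhibition and higher numbers for weaker inhibition), compound 1 gives 960 nM, and compound 2 gives 680 nM; the two numbers lie within the scatter of each other, so no order between them is claimed.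

Compound 3 `CC(C)(C)C[C@@H](O)C(=O)N1C[C@@H]2C[C@@H]2[C@H]1C(=O)NCc1cc(Cl)ccc1-n1cnnn1` carries the core of compound 1 with one change: neopentyl in place of phenyl on a saturated chain carbon bound to a carbonyl carbon and an oxygen on a saturated carbon. In this assay compound 3 gives 910 nM. The step is a 1.1-fold lower number from compound 1 to compound 3 (0.02 log units; within the scatter), so on the core of compound 1 this exchange left the read-out essentially unchanged. Compounds 1, 2 and 3 all sit within the scatter of one another.

Compound 4 `CC(C)(C)C[C@@H](O)C(=O)N1[C@@H]2C[C@@H]2C[C@H]1C(=O)NCc1cc(Cl)ccc1-n1cnnn1` applies the same change to the core of compound 2: neopentyl in place of phenyl on a saturated chain carbon bound to a carbonyl carbon and an oxygen on a saturated carbon. The place of the change reads the same in both cases, so it is the same change made once on each core. Among the compounds with values here, only one measured instance of it exists, and the two cores differ in a way not broken down here, which limits how far that instance carries.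

The step from compound 2 to compound 4 is expected to be a 1.1-fold lower number from compound 2 to compound 4 (0.04 log units; within the scatter). Within the data shown here, this expectation rests on the single measured step of a 1.1-fold lower number from compound 1 to compound 3 (0.02 log units; within the scatter), which stayed within the scatter. Compound 4 is therefore estimated at 620 nM in this assay, with a range from 300 nM to 1300 nM.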

Compound 4, half-maximal inhibitory concentration: 520 nM
For compound 4 the middle estimate is 1.2-fold (0.08 log units) above the measured one; measured number inside the range.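

Neopentyl in place of phenyl on a saturated chain carbon bound to a carbonyl carbon and an oxygen on a saturated carbon now has a measured step on the core of compound 2, where this assay gives a 1.3-fold lower number from compound 2 to compound 4 (0.12 log units; within the scatter). Set beside the step on the core of compound 1, the exchange reads alike on both cores, with neither step leaving the scatter: the same change on two cores in this assay, a 1.1-fold lower number (0.02 log units; within the scatter) from compound 1 to compound 3 and a 1.3-fold lower number (0.12 log units; within the scatter) from compound 2 to compound 4, 1.2-fold (0.09 log units) apart, within the scatter of two such steps. This supports carrying this one exchange between these two cores with no detectable shift in the read-out, but it rests on a single pair of steps, both too small to test whether a real effect would transfer, and it says nothing about other cores, other exchanges or other read-outs.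

Still open, from the compounds shown here alone, is whether an amine, a carboxylic acid or a longer chain in that place would give a step beyond the scatter in this assay, and whether such a step would then carry from one core to the other. Going by these compounds, all four compounds also keep the same chlorine-bearing aromatic amide part, so how a change made there would behave on either core remains unknown.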